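Series notes: cyclopropylcarbonyl in place of oxazolylcarbonyl

A few compounds are considered here, and "the series" means these few. Any claim that something is new, unique, unknown or untested is made for them only; others in the source may bear on it.

Measured so far:
compound 1, `CCn1c(-c2ccc(C(F)(F)F)nc2)nc2c(O[C@H]3CCN(C(=O)c4cocn4)C3)ncnc21`, gives 2
compound 2, `CCn1c(-c2cnc(C)nc2)nc2c(O[C@H]3CCN(C(=O)C4CCC4)C3)ncnc21`, gives 1.3
compound 3, `CCn1c(-c2cnc(C)nc2)nc2c(N[C@H]3CCN(C(=O)[C@H]4C[C@@H](OC)C4)C3)ncnc21`, gives 0.9

In a physicochemical assay for lipophilicity, read by HPLC (a higher number here means a more lipophilic compound, a lower number a more polar compound), compound 1 gives 2, the highest of the three numbers. Compound 2 sits lower by a gap beyond the scatter, and compound 3 lower still, also beyond the scatter. Going by the values given here, no two measured compounds differ in a single place, so no measured step is available to read directly.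

Compound 4, `CCn1c(-c2ccc(C(F)(F)F)nc2)nc2c(O[C@H]3CCN(C(=O)C4CC4)C3)ncnc21`, is not yet measured. It differs from compound 1 in one place: cyclopropyl in place of 1,3-oxazol-4-yl on a carbonyl carbon.

In this assay an upward step is expected, of a size beyond the scatter, a number 0.50 log units higher from compound 1 to compound 4 (beyond the scatter). Compound 4 is therefore expected to give about 2.5, within a range from 2.1 to 2.9.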

Compound 4, distribution coefficient: 2.3
Estimate against measurement, compound 4: 0.20 log units above; the range from low to high includes it.
By their numbers in this assay, from the lowest: compound 3; then compound 2; then compounds 1 and 4 (each within the scatter of the next).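

In this assay, the series now has its first single-place step, a number 0.30 log units higher from compound 1 to compound 4 (within the scatter), on a carbonyl carbon whose other neighbour is an amide-type nitrogen in a ring. At this position, the exchange of 1,3-oxazol-4-yl for cyclopropyl therefore gives no separation between compound 1 and compound 4 in this read-out. No available evidence bears on this result. The compounds shown leave open how a longer alkyl chain or a dimethylamino group would read on the same carbonyl carbon.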